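The compounds below may be only part of what the source reports. "The series", "measured", "known", "first", "only" and "open" are said of these compounds alone.

Measured compounds:
Compound 1 `O=C(N/N=C/c1ccc(O)cc1)c1cccnc1Nc1cccc(C(F)(F)F)c1` gives 59.5%.
Compound 2 `COc1cc(/C=N/NC(=O)c2cccnc2Nc2cccc(C(F)(F)F)c2)cc(OC)c1OC` gives 28.5%.
Compound 3 `O=C(N/N=C/c1cccnc1)c1cccnc1Nc1cccc(C(F)(F)F)c1` gives 52.4%.

In a functional assay on the whole organism (strain Wistar) for inhibition, with Rattus norvegicus as the target, read by paw edema, with a stated time of 3 h, at a dose of 10 mg/kg by the intraperitoneal route (a higher number here means more inhibition at the dose given (going by the name of the read-out), a lower number less inhibition), compound 1 holds the highest of the three numbers; compound 3 lies nearest to it, and the step of a number 7.1 percentage points lower from compound 1 to compound 3 (within the scatter) stays within the scatter, while compound 2 sits furthest from compound 1, beyond the scatter. The unmeasured compound 4 `O=C(N/N=C/c1ccncc1)c1cccnc1Nc1cccc(C(F)(F)F)c1` differs from compound 1 in one place: pyridin-4-yl in place of 4-hydroxyphenyl on a carbon with a double bond to nitrogen. Among the measured compounds shown here, the only measured step that bears on this change is a number 7.1 percentage points lower from compound 1 to compound 3 (within the scatter), where a pyridin-3-yl also replaced 4-hydroxyphenyl on the same carbon with a double bond to nitrogen, and the number hardly moved. Compound 4 is therefore expected to land close to compound 1 in this assay, with a step of a number 7.5 percentage points lower from compound 1 to compound 4 (within the scatter) not beyond the scatter. Compound 4 is estimated at 52%, within 38% to 66%.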

Compound 4, a percentage reported as inhibition, in the whole organism at one dose (the size of the read-out at that dose, not a potency): 54.9%
For compound 4 the middle estimate is 2.9 percentage points below the measured one; the range from low to high includes it.
By their numbers in this assay, from the lowest: compound 2; then compounds 3, 4 and 1 (each within the scatter of the next).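

In this assay, pyridin-4-yl in place of 4-hydroxyphenyl on the carbon with a double bond to nitrogen gives a number 4.6 percentage points lower from compound 1 to compound 4 (within the scatter), so a second pyridine ring now behaves at this position as the first did. Pyridin-4-yl in place of pyridin-3-yl gives a number 2.5 percentage points higher from compound 3 to compound 4 (within the scatter), so the two pyridine rings cannot be told apart here. Nothing available explains why these numbers stay together. The compounds shown leave open whether pyridin-2-yl would stay with them, and whether a phenyl ring carrying an amine or a carboxylic acid would.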